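Methyl for methoxy on two cinnamoyl cores, cytotoxicity expected flat

The source may report more compounds than this note shows. Statements on the series, on what has been measured and on what is new or still open speak of the compounds shown alone.

Measured compounds:
Compound 1, `COC(=O)[C@H](CO)NC(=O)/C=C/c1ccc(OC)cc1`: 100%
Compound 2, `COC(=O)[C@H](CO)NC(=O)/C=C/c1ccc(C)cc1`: 100%
Compound 3, `COC(=O)[C@@H]1COC(/C=C/c2ccc(OC)cc2)=N1`: 94.8%

Of the compounds shown here, three have been tested in an ADME assay on Vero cells (Chlorocebus sabaeus) for cytotoxicity, read by WST assay, tested at 50 ug/mL; on this read-out higher numbers stand for a weaker effect at the one concentration tested and lower numbers for a stronger effect. Compound 1 `COC(=O)[C@H](CO)NC(=O)/C=C/c1ccc(OC)cc1` gives 100%, compound 2 `COC(=O)[C@H](CO)NC(=O)/C=C/c1ccc(C)cc1` gives 100%, and compound 3 `COC(=O)[C@@H]1COC(/C=C/c2ccc(OC)cc2)=N1` gives 94.8%. All three numbers lie within the scatter of one another, so none of them can be said to differ from the rest in this assay.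

Compound 1 and compound 2 share a core and differ only by methyl in place of methoxy on an aromatic carbon. This change gave no change at the digits printed from compound 1 to compound 2 (within the scatter).

Compound 3 carries a different core; the difference between the two cores is not broken down here. Compound 4 `COC(=O)[C@@H]1COC(/C=C/c2ccc(C)cc2)=N1` has not yet been measured. It differs from compound 3 by methyl in place of methoxy on an aromatic carbon, the same change as that from compound 1 to compound 2, at a place described in the same words.

Going by the values given here, since the one measured instance of this change, no change at the digits printed from compound 1 to compound 2 (within the scatter), stayed within the scatter, compound 4 is expected to stay close to compound 3, with a step of a number 0.2 percentage points higher from compound 3 to compound 4 (within the scatter) in this assay. The estimate for compound 4 in this assay is 95%, expected to fall between 85% and 100%. Among the compounds with values here, this rests only on the single pair compound 1 and compound 2; no second instance on the core of compound 3 exists.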

Compound 4, a percentage reported as activity, at one concentration (the size of the read-out at that concentration, not a potency): 85.1%
Compound 4: middle estimate off by 9.9 percentage points, on the high side; the measured number falls inside the stated range.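

In this assay, methyl in place of methoxy on an aromatic carbon, para to a large group, gave a number 9.7 percentage points lower from compound 3 to compound 4 (within the scatter), and this step does not differ from the one seen on the other core: the same change on two cores in this assay, no change at the digits printed (within the scatter) from compound 1 to compound 2 and a number 9.7 percentage points lower (within the scatter) from compound 3 to compound 4, 9.7 percentage points apart, within the scatter of two such steps

On these two cores, then, the change carries over within the scatter: neither step can be told apart from no change, and nothing in the pair of steps marks one core as responding differently from the other. Going by these compounds alone, this does not show that the change is without effect in general, nor that it would carry over to a third core, since the comparison rests on only two pairs, each read at a single concentration that gives a size of effect and not a potency.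

The compounds shown leave open how other groups at the same place on the aromatic ring, such as a chlorine atom, a nitrile or an amine, would read in this assay. They also leave open whether the same step would hold on either core if its methyl ester gave way to a carboxylic acid or to an ester with a longer chain.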